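Chain length between aniline nitrogen and ester, compound 4

The compounds below may be only part of what the source reports. "The series", "measured", "known", "first", "only" and "open" are said of these compounds alone.

Going by the values given here, the three measured members share the core of compound 1 `CCOC(=O)CN(c1ccccc1)[C@H]1c2cc(C#N)ccc2OC(C)(C)[C@@H]1O`, all read in a functional assay (aorta) with Rattus norvegicus as the target; a higher number here means a weaker inhibitor, a lower number a stronger inhibitor. Compound 1 gives only a limit, > 30000 nM. Compound 2 `CC1(C)Oc2ccc(C#N)cc2[C@H](N(CC(=O)O)c2ccccc2)[C@H]1O` also gives only a limit, > 100000 nM. Among the compounds with values here, compound 3 `CCOC(=O)CCN(c1ccccc1)[C@H]1c2cc(C#N)ccc2OC(C)(C)[C@@H]1O` gives 54000 nM, the single number among the three values. Compound 4 `CCOC(=O)CCCN(c1ccccc1)[C@H]1c2cc(C#N)ccc2OC(C)(C)[C@@H]1O` differs from compound 3 by (ethoxycarbonyl)methyl in place of ethoxycarbonyl on a saturated chain carbon, two bonds along the chain from a nitrogen on an aromatic ring. Of the measured steps, a step that the limit leaves unreadable from compound 1 to compound 3 is the same kind of chain extension, but it cannot be read because of the limit of > 30000 nM in this assay, at which 1 of the 3 values shown sits. The steps of an at least 1.8-fold lower number from compound 2 to compound 3 (0.26 log units; that floor lies within the scatter) and a step that the two limits leave unreadable from compound 1 to compound 2 concern the exchange of acid for ester and bear only indirectly. No readable step of the same kind exists, so no change beyond the scatter is expected in this assay. Compound 4 is expected at 55000 nM, within a range of 25000 nM to 120000 nM. The expected step, a 1.0-fold higher number from compound 3 to compound 4 (0.01 log units; within the scatter), is estimated to stay within the scatter.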

Compound 4, half-maximal inhibitory concentration: > 30000 nM
Compound 4: only a limit was reported (the forecaster's own chance of this, stated with the estimate: 40%); the middle value is on the limit's open side.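

In this assay, going by these compounds alone, compound 4 gives only a limit, so no step from compound 1, compound 2 or compound 3 to compound 4 can be read: the limit of > 30000 nM in this assay, at which 2 of the 4 values shown sit. The compounds shown leave open whether 3-(ethoxycarbonyl)propyl differs from 2-(ethoxycarbonyl)ethyl in this read-out.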